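A few compounds are considered here, and "the series" means these few. Any claim that something is new, unique, unknown or untested is made for them only; others in the source may bear on it.

Measured in a functional assay on IMR-32 cells (Homo sapiens) for cytotoxicity; a higher number here means a weaker inhibitor, a lower number a stronger inhibitor:
- compound 1, `COc1ccc(C2C(OC(C)=O)C(=O)N2c2cc(OC)c(OC)c(OC)c2)cc1`: 251 nM
- compound 2, `COc1ccc2cc(C3C(OC(C)=O)C(=O)N3c3cc(OC)c(OC)c(OC)c3)ccc2c1`: > 1000 nM (a limit of the assay, not a number)

Compound 2 stands only at the limit of > 1000 nM in this assay, at which 1 of the 2 values shown sits; its own value is not pinned down. Compound 1, by contrast, gives a measured number in this assay, so of the two only compound 1 is placed on the scale. Within the data shown here, the two differ in more than one place, so no single step between them is counted here; the values show only that compound 1 falls inside the measured range and compound 2 does not.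

Compound 3, `COc1ccc2cc(C3C(O)C(=O)N3c3cc(OC)c(OC)c(OC)c3)ccc2c1`, differs from compound 2 by hydrogen in place of acetyl on an oxygen on a saturated carbon. Among the measured compounds shown here, no measured pair carries this change, so its size is unknown. The step expected is a step that the limit leaves unreadable from compound 2 to compound 3, with no clear direction beyond the usual scatter. Compound 3 is therefore estimated at 1500 nM, with a range from 300 nM to 6000 nM, and a fair chance that only a limit is reported again.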

Compound 3, half-maximal inhibitory concentration: 89 nM
Compound 3: middle estimate off by 17-fold (1.23 log units), on the high side; measured number below the stated range.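

Acetoxy to hydroxy on the oxygen on a saturated carbon is the first single-place change in this series that can be read, and in this assay it gives an at least 11-fold lower number from compound 2 to compound 3 (1.05 log units; beyond the scatter). On these data alone, compound 2 stands at a limit of the assay and not at a number, so the step is a minimum and its full size stays unknown: the limit of > 1000 nM in this assay, at which 1 of the 3 values shown sits. With hydroxy in place of acetoxy, the core of compound 2 comes onto the measured scale, with compound 3 at 89 nM.

Whether the same change moves compound 1, at 251 nM, in the same direction remains open, so the effect is shown on one core only. Also open, as far as these compounds go, is what an amine or a methyl ether would give at this place.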